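Anilino-imidazopyrazine series: halogenated phenyl variants on the core

The compounds below may be only part of what the source reports. "The series", "measured", "known", "first", "only" and "open" are said of these compounds alone.

Compound 1 `Cc1n[nH]c2ccc(-c3nc4cnc(N5CCN(C)CC5)cn4c3Nc3ccc(F)cc3)cc12` carries a 4-fluorophenyl group on the amine of the shared core. In a functional assay on CWR22R cells (Homo sapiens) for inhibition, with a stated time of 120 h (a higher number here means a weaker inhibitor, a lower number a stronger inhibitor), compound 1 gives 33600 nM. Compound 2 `Cc1ccc(C)c(Nc2c(-c3ccc4[nH]nc(C)c4c3)nc3cnc(N4CCN(C)CC4)cn23)c1` has no result in this assay "not determined" (no result reported). Compound 3 `Cc1n[nH]c2ccc(-c3nc4cnc(N5CCN(C)CC5)cn4c3Nc3ccc(Br)cc3Cl)cc12` likewise has no result in this assay "not determined" (no result reported); compound 3 therefore stands on no single number, and the only figure in the series is the weak one from compound 1. Compound 4 `Cc1n[nH]c2ccc(-c3nc4cnc(N5CCN(C)CC5)cn4c3Nc3ccc(F)c(Cl)c3)cc12` differs from compound 3 by 3-chloro-4-fluorophenyl in place of 4-bromo-2-chlorophenyl on a nitrogen on an aromatic ring. Within the data shown here, no step between measured compounds is available for this change, so nothing about its size or direction can be read from the series; the expectation rests on compound 1 alone. Given that compound 1 gives 33600 nM, a step of no more than the usual scatter in either direction is expected for compound 4. Compound 4 is estimated at 25000 nM in this assay, expected between 6000 nM and 100000 nM.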

Compound 4, half-maximal inhibitory concentration: 14000 nM
Compound 4: middle estimate off by 1.8-fold (0.25 log units), on the high side, and the stated range covers the measured number.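

In this assay the aryl group on the amine of the shared core gains its first measured step: chloro in place of hydrogen on an aromatic carbon, turning 4-fluorophenyl into 3-chloro-4-fluorophenyl, gives a 2.4-fold lower number from compound 1 to compound 4 (0.38 log units; beyond the scatter) and so moves the number beyond the scatter. The step is modest, and compound 4 at 14000 nM remains a weak inhibitor, so one added chloro does not change the standing of the series. No evidence at hand accounts for the step.

Steps to compound 2 and compound 3 cannot be read, so the change from 4-bromo-2-chlorophenyl to 3-chloro-4-fluorophenyl has no size. On these data alone, whether methoxy, nitrile or an amine in place of that chloro would shift the number further stays open.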